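Swapping an anilino link for a phenoxy link on a shared core

The source may report more compounds than this note shows. Statements on the series, on what has been measured and on what is new or still open speak of the compounds shown alone.

Measured so far:
Compound 1 `Cc1ccc(Nc2ncc3c(n2)N(C)C(=O)N(c2cc(NC(=O)c4cccc(C(F)(F)F)c4)ccc2C)C3)cc1N(C)C`: > 10000 nM
Compound 2 `Cc1ccc(Nc2ncc3c(n2)N(C)C(=O)N(c2cc(NC(=O)c4cc(C(C)(C)C)cc(C(C)(C)C)c4)ccc2C)C3)cc1N`: > 10000 nM

Both compounds were tested in an ADME assay on BaF3 cells (Mus musculus) for antiproliferative activity, read by CellTiter-Glo and CCK-8 assay, with a stated time of 72 h; a higher number here means a weaker inhibitor of growth, a lower number a stronger inhibitor of growth. In this assay compound 1 gives > 10000 nM, which is a limit of the assay rather than a number. In this assay compound 2 also gives > 10000 nM, again a limit. Among the compounds with values here, compound 1 therefore stands where every value so far stands: the limit of > 10000 nM in this assay, at which 2 of the 2 values shown sit. Within the data shown here, no step between two measured compounds can be read from these two limits, and nothing in them points to a direction for a change.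

Compound 3 `Cc1ccc(Oc2ncc3c(n2)N(C)C(=O)N(c2cc(NC(=O)c4cccc(C(F)(F)F)c4)ccc2C)C3)cc1N` is not yet measured. It differs from compound 1 in one place: 3-amino-4-methylphenoxy in place of (3-(dimethylamino)-4-methylphenyl)amino on an aromatic carbon. Among the measured compounds shown here, both measured compounds carry the anilino link and both sit at the limit, and no measured pair shows what the phenoxy link or the free amine does. The expected step from compound 1 to compound 3 is a number no higher from compound 1 to compound 3 (the limit leaves the size open), which is taken as none beyond the scatter. Compound 3 is therefore estimated at 10000 nM in this assay, within a range from 2500 nM to 40000 nM, with a real chance that only a limit is reported again.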

Compound 3, concentration for 50% growth inhibition: > 10000 nM
Compound 3 gave a limit, no number; the forecaster's own chance of this, stated with the estimate: 65%; the middle value lies on the limit itself.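

Within the data shown here, compound 3, like compound 1, gives only a limit of the assay and not a number, so no step between the two can be read; every value shown sits at the same limit: the limit of > 10000 nM in this assay, at which 3 of the 3 values shown sit. The compounds shown leave open whether the phenoxy link or the anilino link makes any difference, and which change to the shared core would give a number rather than a limit.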